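Tert-Butyl to Methyl Ester: Expected Shift in Cell Inhibition

The compounds below may be only part of what the source reports. "The series", "measured", "known", "first", "only" and "open" are said of these compounds alone.

Going by the values given here, compound 2 `CC(C)(C)OC(=O)/C=C\NC(=O)[C@@H](O)C(C)(C)CO` is the only compound in this set with a number: in an ADME assay on WI-38 cells (Homo sapiens) for inhibition, read by CellTiter-Glo, with a stated time of 48 h, tested at 100 uM (on this read-out higher numbers stand for more inhibition at the one concentration tested (going by the name of the read-out) and lower numbers for less inhibition), compound 2 gives 26%. Compound 1 `COC(=O)/C=C\NC(=O)[C@H](O)C(C)(C)CO` was entered in this assay as well, where compound 1 gives "not determined" (no result reported), so no number stands for it. Compound 3 `COC(=O)/C=C\NC(=O)[C@@H](O)C(C)(C)CO` differs from compound 2 by methyl in place of tert-butyl on an oxygen next to a carbonyl group. Among the compounds with values here, no measured pair with a step exists here, so the size of such a step has not been observed. Only a shift within the scatter, or at most a modest drop, is expected. For compound 3 the expected step is a number 6 percentage points lower from compound 2 to compound 3 (within the scatter). The estimate for compound 3 in this assay is 20%, within 5% to 38%.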

Compound 3, a percentage reported as inhibition, at one concentration (the size of the read-out at that concentration, not a potency): -20%
Compound 3: the middle estimate sits 40 percentage points above what was measured; measured number outside the range, below it.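

This position is not indifferent to the ester group: in this assay, methyl in place of tert-butyl on an oxygen next to a carbonyl group gives a number 46 percentage points lower from compound 2 to compound 3 (beyond the scatter). One measured pair now shows that this single change can move the read-out well past ordinary scatter. Nothing available here explains the size of the step.

On these data alone, whether an ethyl ester or a carboxylic acid at this place would fall between compound 2 and compound 3 stays open. The role of configuration also stays open, as compound 1 has no number, although it is the closest comparison for compound 3: the fact that compounds 1 and 3 differ only in the configuration as drawn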